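Methyl Added to the Benzyl Ring of a Propargylamine Amide

The compounds below may be only part of what the source reports. "The series", "measured", "known", "first", "only" and "open" are said of these compounds alone.

Measured compounds:
Compound 1, `CC1(C)C[C@@H](C(N)=O)N(Cc2ccc(OCc3cccc(F)c3)cc2F)C1`, in an assay on Sf9 cells for inhibition of Amine oxidase [flavin-containing] B (Homo sapiens), with stated times of 15 min and 60 min (on this read-out higher numbers stand for weaker inhibition and lower numbers for stronger inhibition), gives 6350 nM.
Compound 2, `C#CCN(Cc1ccc(OCc2cccc(F)c2)cc1)[C@@H](C)C(N)=O`, in this assay gives 530 nM.

Of the two numbers shown, compound 2 has the lower one, which on this read-out means stronger inhibition. The number for compound 1 is higher, and the gap between the two is larger than the usual scatter of repeated measurements; the two compounds differ in more than one part of their structure, so the data allow no single change to be singled out as the cause.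

Compound 3, `C#CCN(Cc1ccc(OCc2cccc(F)c2)cc1C)[C@@H](C)C(N)=O`, has not yet been measured. It differs from compound 2 in one place: methyl in place of hydrogen on an aromatic carbon. Within the data shown here, with no pair of measured compounds that differ in exactly this way, the size of the step has to be guessed. The expectation is for a small change in this assay, if any beyond the scatter, with a slight lean toward a higher number, giving an expected step of a 1.4-fold higher number from compound 2 to compound 3 (0.15 log units; within the scatter). For compound 3 the estimated value is therefore 750 nM, within a range of 250 nM to 2500 nM.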

Compound 3, half-maximal inhibitory concentration: 320 nM
The estimate for compound 3 lay 2.3-fold (0.37 log units) above the measured number; the range from low to high includes it.
By their numbers in this assay, from the lowest: compounds 3 and 2 (each within the scatter of the next); then compound 1.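

Among these compounds, this is the first comparison here in which only one place differs, so it can be read in a way the gap between compound 1 and compound 2 cannot. In this assay, placing methyl on an aromatic carbon of the six-membered ring, ortho to a large group, gives a 1.7-fold lower number from compound 2 to compound 3 (0.22 log units; within the scatter) and stays within the scatter, so compound 2 and compound 3 cannot be told apart on this read-out, and this carbon can carry a methyl with no difference that this measurement can resolve. No measurement shown here offers an explanation for this result.

Going by these compounds, what remains open is how other groups on this same carbon would read in this assay, such as a longer chain like ethyl, a methoxy group or an amine, since a single methyl says little about what larger or differently built groups would do. This one pair also cannot tell whether a methyl at this place would give a similar result on the core of compound 1, which differs from compound 2 in more than one part.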